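The source may report more compounds than this note shows. Statements on the series, on what has been measured and on what is new or still open speak of the compounds shown alone.

Measured compounds:
compound 1, `CCCCC[Se]c1nc(NCc2ccccc2)c2ccccc2n1`: a limit of the assay, > 100000 nM
compound 2, `[SeH]c1nc(NCc2ccccc2)c2ccccc2n1`: a limit of the assay, > 100000 nM
compound 3, `Nc1nc([SeH])nc2ncccc12`: 87700 nM

All three were tested in an ADME assay on BEAS-2B cells (Homo sapiens) for cytotoxicity, read by MTT assay, with a stated time of 72 h; a lower number here means a stronger inhibitor of growth, a higher number a weaker inhibitor of growth. Compound 2 and compound 1 differ in one place, (pentyl in place of hydrogen on a selenium), yet the step that the two limits leave unreadable from compound 2 to compound 1 cannot be sized, since both values sit at the limit of > 100000 nM in this assay, at which 2 of the 3 values shown sit. Compound 3 carries a different core from compound 2; the difference between the two cores is not broken down here. Compound 3 is the only one of the three for which this assay returned a number rather than a limit.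

Compound 4, `CCCCC[Se]c1nc(N)c2cccnc2n1`, has not been measured. It differs from compound 3 by pentyl in place of hydrogen on a selenium, the same change as that from compound 2 to compound 1. The earlier instance of this change gave no readable step, so the expectation for compound 4 rests mainly on compound 3 itself, whose value is 87700 nM. The step from compound 3 to compound 4 is estimated to be a 1.0-fold higher number from compound 3 to compound 4 (0.01 log units; within the scatter). Compound 4 is therefore expected to give about 90000 nM in this assay, estimated to lie between 30000 nM and 300000 nM.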

Compound 4, concentration for total growth inhibition: 44900 nM
For compound 4 the middle estimate is 2.0-fold (0.30 log units) above the measured one; low and high end bracket the measured number.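

In this assay, pentyl in place of hydrogen on a selenium on the core of compound 3 gives a 2.0-fold lower number from compound 3 to compound 4 (0.29 log units; within the scatter), so on this core the change cannot be told apart from repeat measurement. The same change on the core of compound 2 cannot be read, and so no size can be set beside this step, since both of those compounds give only a limit of the assay: the limit of > 100000 nM in this assay, at which 2 of the 4 values shown sit.

This single readable step therefore does not show that the change carries from one core to the other, and it does not show that it fails to carry.

The compounds shown leave open whether another group on the selenium, such as a chain longer than pentyl or a chain ending in an amine or a carboxylic acid, gives a step beyond the scatter on the core of compound 3. They also leave open how the pentyl change behaves on a core where both partners return a number rather than a limit.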